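This account rests on a few compounds, and the source may have more. Where it says the series, first, only, none or still open, it means among the compounds named here.

Compound 2 `O=C(/C(=C\c1ccc(O)c([N+](=O)[O-])c1)SCc1ccc(Br)cc1)c1ccc(Br)cc1` is one of three compounds in this series that have been examined in a functional assay on DU-145 cells (Homo sapiens) for inhibition, read by trypan blue exclusion, with a stated time of 96 h (a higher number here means a weaker inhibitor of growth, a lower number a stronger inhibitor of growth), where compound 2 gives 10000 nM. Compound 1 `O=C(/C(=C\c1ccc(O)c([N+](=O)[O-])c1)SCc1ccc(Br)cc1)c1c(F)c(F)c(F)c(F)c1F` gives 10000 nM in this assay, and compound 3 `O=C(/C(=C\c1ccc(O)c([N+](=O)[O-])c1)SCc1ccc(Br)cc1)c1ccc(Cl)cc1Cl` gives 10000 nM, so compound 2 stands level with both at the digits shown, nearest to compound 1 and furthest from compound 3 only in the order of the record, not in the numbers. The three known steps all alter the group on the carbonyl carbon: no change at the digits printed from compound 1 to compound 2 (within the scatter), no change at the digits printed from compound 1 to compound 3 (within the scatter) and no change at the digits printed from compound 2 to compound 3 (within the scatter). Compound 4 `O=C(/C(=C\c1cc(I)c(O)c(I)c1)SCc1ccc(Br)cc1)c1ccc(Br)cc1` differs from compound 2 elsewhere: 4-hydroxy-3,5-diiodophenyl in place of 4-hydroxy-3-nitrophenyl on a double-bonded chain carbon bound to a double-bonded chain carbon. Within the data shown here, no measured step touches this group, so the known steps bear on the change only in that none of them moved the number. Among the measured compounds shown here, one therefore expects no step beyond the scatter, namely no change at the digits printed from compound 2 to compound 4 (within the scatter), with a wide range because no step at this position is on record. For compound 4 the estimate is 10000 nM, between 3000 nM and 30000 nM.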

Compound 4, concentration for 50% growth inhibition: 1000 nM
Beside the measured number, compound 4's estimate is 10-fold (1.00 log units) above it; measured number outside the range, below it.
By their numbers in this assay, from the lowest: compound 4; then compounds 1, 2 and 3 (each within the scatter of the next).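

In this assay, the group on a double-bonded chain carbon bound to a double-bonded chain carbon is the only place in this set where a single change moves the number beyond the scatter: 4-hydroxy-3,5-diiodophenyl in place of 4-hydroxy-3-nitrophenyl gives a 10-fold lower number from compound 2 to compound 4 (1.00 log units; beyond the scatter) and so separates this position from the carbonyl carbon, where the three steps shown left the number unchanged at the digits printed. The change swaps the nitro group for iodine as well as adding a second iodine, and this single pair cannot divide the step between those two parts. Nothing measured here accounts for the step.

On these data alone, it remains open how the number would respond to a group carrying a single iodine, or to bromine or an amine at this position. As far as these compounds go, it is also open whether the groups on the carbonyl carbon would remain without effect alongside 4-hydroxy-3,5-diiodophenyl.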